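The compounds below may be only part of what the source reports. "The series", "measured", "known", "first", "only" and "open" are said of these compounds alone.

Measured compounds:
- compound 1, `COc1ccc(N)c(C2=NN(C(C)=O)C(C)(C)S2)c1`, 77.1%
- compound 2, `COc1ccc(N)c(C2=NN(C(=O)C3CCCC3)C(C)(C)S2)c1`, 65%

In an assay on isolated protein for inhibition of Nitric oxide synthase, inducible (Homo sapiens), read by scintillation counting, with a stated time of 30 min, tested at 50 uM (on this read-out lower numbers stand for less inhibition and higher numbers for more inhibition at the one concentration tested (going by the name of the read-out)), compound 1 gives 77.1%, the higher of the two numbers shown; compound 2 gives 65%. Among the measured compounds shown here, the one measured step, a number 12.1 percentage points lower from compound 1 to compound 2 (beyond the scatter), is a modest loss and concerns the group on the carbonyl carbon, a different part of the molecule.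

Compound 3, `CC(=O)N1N=C(c2ccccc2N)SC1(C)C`, is not yet measured. It differs from compound 1 in one place: hydrogen in place of methoxy on an aromatic carbon, on an aromatic carbon of a six-membered aromatic ring of carbon only, para to an amino group. No measured step touches this ring, so nothing shown tells how much weight the methoxy carries. A small group is removed, and a modest loss within or near the scatter is expected, with wide uncertainty. For compound 3 the expected step is a number 12.1 percentage points lower from compound 1 to compound 3 (beyond the scatter). Compound 3 is estimated at 65%, between 45% and 82%.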

Compound 3, a percentage reported as inhibition, at one concentration (the size of the read-out at that concentration, not a potency): 22.9%
Estimate against measurement, compound 3: 42.1 percentage points above; measured number outside the range, below it.
By their numbers in this assay, from the lowest: compound 3; then compound 2; then compound 1.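

Replacing the methoxy with hydrogen, on the aromatic carbon para to an amino group, gives in this assay a number 54.2 percentage points lower from compound 1 to compound 3 (beyond the scatter) and so shows that this position matters greatly for the inhibition seen at the one concentration tested. Among the compounds shown here, this large step also outweighs the modest change at the carbonyl carbon, where the earlier compounds showed a number 12.1 percentage points lower from compound 1 to compound 2 (beyond the scatter) and gave no view of the ring at all. No measurement shown offers a reason for the size of this loss.

Going by these compounds, with only methoxy and hydrogen compared at this position, it remains open whether a hydroxy group, an ethoxy group or a chlorine atom in the same place would keep the inhibition. Also open, on these data alone, is whether removing the methoxy costs as much when cyclopentyl replaces methyl on the carbonyl carbon.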